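The source may report more compounds than this note shows. Statements on the series, on what has been measured and on what is new or still open speak of the compounds shown alone.

Four compounds share one core and differ only in the group at one end. In a functional assay on A549 cells (Homo sapiens) for cytotoxicity, read by MTT assay, with a stated time of 72 h (on this read-out lower numbers stand for stronger inhibition and higher numbers for weaker inhibition), compound 1 `CN(C)CCn1cnnc1-c1cc(Oc2ccc(NC(=O)N/N=C/c3cc(C(C)(C)C)cc(C(C)(C)C)c3O)cc2F)ccn1` gives 980 nM, while compound 3 `Cn1cnnc1-c1cc(Oc2ccc(NC(=O)N/N=C/c3ccccc3)cc2F)ccn1` gives 7560 nM. Compound 2 `CN(C)CCn1cnnc1-c1cc(Oc2ccc(NC(=O)N/N=C/c3ccc(O)c(O)c3)cc2F)ccn1` reaches only a limit of this assay, > 100000 nM, so no true number is known for it. That puts compound 2 at the limit of > 100000 nM in this assay, at which 1 of the 3 values shown sits. Compound 4 `CN(C)CCn1cnnc1-c1cc(Oc2ccc(NC(=O)N/N=C/c3cccc(O)c3)cc2F)ccn1` differs from compound 2 by hydrogen in place of hydroxy on an aromatic carbon; cut one bond further out, the change reads 3,4-dihydroxyphenyl to 3-hydroxyphenyl. Within the data shown here, no measured pair shows this exact step, so its size is uncertain. The expected step of an at least 5.0-fold lower number from compound 2 to compound 4 (0.69 log units; beyond the scatter) is toward stronger inhibition, beyond the usual scatter. Compound 4 is estimated at 20000 nM, with a range from 5000 nM to 100000 nM.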

Compound 4, half-maximal inhibitory concentration: > 100000 nM
Compound 4 ended at the assay's limit; the forecaster's own chance of this, stated with the estimate: 25%; at least 5.0-fold (0.69 log units) between middle value and limit.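

Compound 2 and compound 4 both stand at a limit, not at a true number, so no step can be read between them: the limit of > 100000 nM in this assay, at which 2 of the 4 values shown sit.

Going by these compounds, whether hydrogen in place of hydroxy changes inhibition at all stays open, as does the true number of either compound.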